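The source may report more compounds than this note shows. Statements on the series, on what has been measured and on what is new or still open speak of the compounds shown alone.

Compound 1 `CC[Si](CC)(CC)C/C1=C/C[C@](C)(CCC=C(C)C)/C=C/[C@@H](OC(=O)C=C(C)C)[C@](C)(O)/C=C/C1=O`: 3150 nM
Compound 2 `CC(C)=CCC[C@]1(C)/C=C/[C@@H](OC(=O)C=C(C)C)[C@](C)(O)/C=C/C(=O)/C(COC(=O)c2ccc([N+](=O)[O-])cc2)=C\C1`: 670 nM

Both numbers come from a functional assay on MCF7 cells (Homo sapiens) for antiproliferative activity, read by MTT assay, with a stated time of 48 h; on this read-out lower numbers stand for stronger inhibition and higher numbers for weaker inhibition. For the measured compounds named here, compound 2 holds the lower number of the pair, and the only measured step is a 4.7-fold lower number from compound 1 to compound 2 (0.67 log units; beyond the scatter).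

The next structure is compound 3 `CSC(=S)OC/C1=C/C[C@](C)(CCC=C(C)C)/C=C/[C@@H](OC(=O)C=C(C)C)[C@](C)(O)/C=C/C1=O`, which differs from compound 2 by a group of 4 heavy atoms (2 carbon, 2 sulfur; no ring) in place of a group of 11 heavy atoms (7 carbon, 1 nitrogen, 3 oxygen; one six-membered aromatic ring of carbon only), on an oxygen on a saturated carbon. The (4-nitrophenyl)carbonyl leaves, taking the aromatic ring with it, and the entering group has no common name. Going by the values given here, no measured compound carries that group, so the evidence is thin. Among the compounds with values here, compound 1, at 3150 nM, also has no such ring, and the one step that bears on this change was modest. Part of that gain may therefore be lost, so a move to a higher number is expected in this assay, with an estimated step of a 2.2-fold higher number from compound 2 to compound 3 (0.35 log units; beyond the scatter). For compound 3 the estimated value is 1500 nM, with an expected range of 450 nM to 5000 nM.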

Compound 3, half-maximal inhibitory concentration: 900 nM
Compound 3: middle estimate off by 1.7-fold (0.22 log units), on the high side; the measured number falls inside the stated range.
By their numbers in this assay, from the lowest: compounds 2 and 3 (each within the scatter of the next); then compound 1.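

In this assay, the step of a 1.3-fold higher number from compound 2 to compound 3 (0.13 log units; within the scatter) shows that the aromatic ring of the (4-nitrophenyl)carbonyl is not required to keep the number at this level, since a much smaller sulfur-bearing group on the same oxygen serves about as well. The step of a 3.5-fold lower number from compound 1 to compound 3 (0.54 log units; beyond the scatter) adds that the gain over the silicon-bearing group of compound 1 appears with this second, ring-free group too, so in these compounds it does not depend on that ring. Nothing available gives a reason for this result.

Still open, on these data alone, is whether a free hydroxyl on that saturated carbon, a small acetyl on the oxygen, or a plain benzoyl without the nitro group would give a similar number. With so few compounds, each conclusion rests on a single pair.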